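A few compounds are considered here, and "the series" means these few. Any claim that something is new, unique, unknown or untested is made for them only; others in the source may bear on it.

Three compounds share one core and differ only in the aromatic ring that sits on the amide nitrogen. Compound 1 `CC(C)[C@H](C(=O)Nc1ccccn1)c1ccc(Cl)cc1` gives 1400 nM in a functional assay on CHO cells for agonist activity at Free fatty acid receptor 2 (Homo sapiens), read by cAMP accumulation; on this read-out higher numbers stand for weaker inhibition and lower numbers for stronger inhibition. Compound 2 `CC(C)[C@H](C(=O)Nc1cccnn1)c1ccc(Cl)cc1` gives 2300 nM in this assay, and compound 3 `CC(C)[C@H](C(=O)Nc1ncns1)c1ccc(Cl)cc1` gives 2000 nM in this assay. These numbers lie close together: the steps of a 1.6-fold higher number from compound 1 to compound 2 (0.22 log units; within the scatter), a 1.4-fold higher number from compound 1 to compound 3 (0.15 log units; within the scatter) and a 1.2-fold lower number from compound 2 to compound 3 (0.06 log units; within the scatter) all fall within the scatter. Compound 3 therefore stands second highest of the three on paper, but none of the three can be called stronger or weaker than another.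

Compound 4 `CC(C)[C@H](C(=O)Nc1ncc[nH]1)c1ccc(Cl)cc1` has not yet been measured. It differs from compound 3 by 1H-imidazol-2-yl in place of 1,2,4-thiadiazol-5-yl on an amide-type nitrogen. Among the compounds with values here, the steps that bear on this change are the three ring swaps already seen on the same amide nitrogen, and each of them stayed within the scatter. On that basis the expected step in this assay is no change at the digits printed from compound 3 to compound 4 (within the scatter), a change in no firm direction and not beyond the scatter. Compound 4 is accordingly expected to give about 2000 nM, with a likely range from 800 nM to 5000 nM.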

Compound 4, half-maximal inhibitory concentration: 20000 nM
Estimate against measurement, compound 4: 10-fold (1.00 log units) below; measured number above the stated range.
By their numbers in this assay, from the lowest: compounds 1, 3 and 2 (each within the scatter of the next); then compound 4.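

The ring on the amide nitrogen is less forgiving than the first three compounds suggested. In this assay, 1H-imidazol-2-yl brings a 10-fold higher number from compound 3 to compound 4 (1.00 log units; beyond the scatter) and an 8.7-fold higher number from compound 2 to compound 4 (0.94 log units; beyond the scatter) and also a 14-fold higher number from compound 1 to compound 4 (1.15 log units; beyond the scatter), which makes compound 4 the weakest of the four on this read-out. The step from compound 3 keeps a five-membered aromatic ring of 5 heavy atoms, so the size of the ring does not change, while the counts do: the entering ring has 1 hydrogen-bond donor and 1 hydrogen-bond acceptor against 0 and 3 in the ring that leaves. Nothing available here explains why the number moves.

The compounds shown leave open whether the loss tracks the added donor, the fewer acceptors, the missing sulfur or some mix of these, since this single change alters all of them at once. A 1-methyl-1H-imidazol-2-yl ring, with a methyl group in place of the ring hydrogen, or a plain phenyl ring on the same amide nitrogen would help to pull these apart.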